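Moving the sulfur: from compound 3 to compound 4

The source may hold more compounds than are shown below. What is called first, only, known or untested is meant among the compounds shown, and "the series" means these compounds.

Three compounds were measured in a functional assay on NCI-H226 cells (Homo sapiens) for inhibition, read by sulforhodamine B assay, with a stated time of 48 h, tested at 10 uM; on this read-out higher numbers stand for more inhibition at the one concentration tested (going by the name of the read-out) and lower numbers for less inhibition:

Compound 1 `c1ccc(-c2cn3ccnc3c(-c3ccc4ncn(C5CCCCC5)c4c3)n2)cc1` gives 33.9%
Compound 2 `c1ccc2c(-c3cn4ccnc4c(-c4ccc5ncn(C6CCCCC6)c5c4)n3)cccc2c1` gives 9.45%
Compound 3 `c1cn2cc(-c3ccsc3)nc(-c3ccc4ncn(C5CCCCC5)c4c3)c2n1` gives 6.34%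

Compound 3 holds the lowest of these three numbers. The step of a number 27.6 percentage points lower from compound 1 to compound 3 (beyond the scatter) lies beyond the scatter, but the step of a number 3.1 percentage points lower from compound 2 to compound 3 (within the scatter) lies within it, so compound 3 and compound 2 cannot be told apart on these numbers.

Compound 4 `c1csc(-c2cn3ccnc3c(-c3ccc4ncn(C5CCCCC5)c4c3)n2)c1` differs from compound 3 in one place: thiophen-2-yl in place of thiophen-3-yl on an aromatic carbon. Within the data shown here, no measured step exchanges one attachment of the same ring for another, so none bears directly on this change; the only step ending at compound 3, a number 27.6 percentage points lower from compound 1 to compound 3 (beyond the scatter), replaced a different group. With the same atoms merely joined differently, no step beyond the scatter is expected. Compound 4 is therefore expected to give about 8%, plausibly between 0% and 22%. The expected step is a number 1.7 percentage points higher from compound 3 to compound 4 (within the scatter).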

Compound 4, a percentage reported as inhibition, at one concentration (the size of the read-out at that concentration, not a potency): 17.1%
For compound 4 the middle estimate is 9.1 percentage points below the measured one; low and high end bracket the measured number.
By their numbers in this assay, from the lowest: compounds 3, 2 and 4 (each within the scatter of the next, the first and the last beyond it); then compound 1.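

In this assay the step of a number 10.8 percentage points higher from compound 3 to compound 4 (beyond the scatter) shows that the point at which the thiophene ring is joined matters at this position, even with the same atoms. Thiophen-2-yl still falls short of phenyl, as the step of a number 16.8 percentage points lower from compound 1 to compound 4 (beyond the scatter) makes clear, while the step of a number 7.7 percentage points higher from compound 2 to compound 4 (within the scatter) leaves it unresolved from naphthalen-1-yl. Nothing at hand explains why the point of attachment counts. Open questions are whether furan-2-yl and furan-3-yl would differ in the same way, and whether an amine or a carboxylic acid on the phenyl ring would change the number.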